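The source may report more compounds than this note shows. Statements on the series, on what has been measured and on what is new or still open speak of the compounds shown alone.

Series notes. The shared core carries a varying aryl group on one aromatic carbon. Compound 1 `COc1ccc(S(=O)(=O)N2CCc3cccc(-c4ccc(N)cc4)c32)cc1` gives 262 nM in a functional assay on KB-VIN10 cells (Homo sapiens) for inhibition, with a stated time of 72 h; on this read-out lower numbers stand for stronger inhibition and higher numbers for weaker inhibition. Compound 2 `COc1ccc(S(=O)(=O)N2CCc3cccc(-c4ccc(F)nc4)c32)cc1` gives 151 nM in this assay and stands second highest of the three numbers; its neighbours are compound 3 `COc1ccc(S(=O)(=O)N2CCc3cccc(-c4ccc(F)cc4)c32)cc1` at 94.6 nM and compound 1, both within the scatter of it, as a 1.6-fold lower number from compound 2 to compound 3 (0.20 log units; within the scatter) and a 1.7-fold lower number from compound 1 to compound 2 (0.24 log units; within the scatter) show. Compound 4 `COc1ccc(S(=O)(=O)N2CCc3cccc(-c4cccs4)c32)cc1` is the next step from compound 2: thiophen-2-yl in place of 6-fluoropyridin-3-yl on an aromatic carbon. Among the measured compounds shown here, no measured step exchanges a six-membered ring for thiophen-2-yl; the only swap on this carbon, a 1.6-fold lower number from compound 2 to compound 3 (0.20 log units; within the scatter), stayed within the scatter, and the larger 2.8-fold lower number from compound 1 to compound 3 (0.44 log units; beyond the scatter) concerned fluoro for amino. For compound 4 a step within the scatter is therefore expected, a 1.2-fold lower number from compound 2 to compound 4 (0.07 log units; within the scatter). Compound 4 is estimated at 130 nM, between 50 nM and 350 nM.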

Compound 4, half-maximal inhibitory concentration: 251 nM
Compound 4: the middle estimate sits 1.9-fold (0.29 log units) below what was measured, and the stated range covers the measured number.
By their numbers in this assay, from the lowest: compounds 3, 2, 4 and 1 (each within the scatter of the next, the first and the last beyond it).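

Thiophen-2-yl puts a five-membered aromatic ring on this carbon, and in this assay only one of its steps passes the scatter, a 2.7-fold higher number from compound 3 to compound 4 (0.42 log units; beyond the scatter), while a 1.7-fold higher number from compound 2 to compound 4 (0.22 log units; within the scatter) and a 1.0-fold lower number from compound 1 to compound 4 (0.02 log units; within the scatter) stay within it. Ring size alone therefore does not sort the series: compound 1 and compound 2 carry six-membered rings yet remain within the scatter of compound 4, and only compound 3 stands apart from it. Nothing available explains this result.

Open, as far as these compounds go, is whether a fluoro group on the thiophene would bring the number towards that of compound 3. Also open, from the compounds shown here alone, is how a saturated ring such as morpholine or a small alkyl chain would fare on this carbon.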